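What Happens When Compound 3 Loses Its Trifluoromethyl Group

The compounds below may be only part of what the source reports. "The series", "measured", "known", "first", "only" and "open" are said of these compounds alone.

Of the compounds shown here, three that share one core have been tested so far in a functional assay on NCI-H460 cells (Homo sapiens) for cytotoxicity, read by MTT assay, with a stated time of 68 h (on this read-out higher numbers stand for weaker inhibition and lower numbers for stronger inhibition), and only two of them give a measured number. Compound 3 (`O=C(Nc1cccc(-c2cccc(C(F)(F)F)c2)c1)C(Cl)Cl`) gives 30200 nM in this test, and compound 1 (`Cc1ccccc1-c1cccc(NC(=O)C(Cl)Cl)c1`) gives 31600 nM in the same test. These two values lie within the scatter of repeated measurements, so compound 3 stands level with compound 1. Compound 2 (`O=C(Nc1cccc(-c2ccsc2)c1)C(Cl)Cl`) reads > 50000 nM here, which is a limit of the assay and not a number.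

The next compound, compound 4 (`O=C(Nc1cccc(-c2ccccc2)c1)C(Cl)Cl`), has hydrogen in place of trifluoromethyl on an aromatic carbon of compound 3. Among the compounds with values here, no two measured compounds differ in just one place, so no measured step shows what such a change does. Within the data shown here, the only guide is that compound 3 at 30200 nM and compound 1 at 31600 nM carry different groups yet remain within the scatter of each other. A small step is therefore expected in this assay rather than a large one. The estimated step of a 1.3-fold higher number from compound 3 to compound 4 (0.10 log units; within the scatter) stays within the scatter, leaning slightly toward weaker inhibition. Compound 4 is expected to give 38000 nM within an estimated range of 18000 nM to 75000 nM when tested.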

Compound 4, half-maximal inhibitory concentration: 20200 nM
Compound 4: the middle estimate sits 1.9-fold (0.27 log units) above what was measured, and the stated range covers the measured number.
By their numbers in this assay, from the lowest: compounds 4, 3 and 1 (each within the scatter of the next). At a limit, above all of these: compound 2.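

In this assay, within the data shown here, this is the first direct reading of the change, and trifluoromethyl and hydrogen on this aromatic carbon leave the two compounds level, with a 1.5-fold lower number from compound 3 to compound 4 (0.17 log units; within the scatter), while hydrogen in place of methyl in the other single change gives a 1.6-fold lower number from compound 1 to compound 4 (0.19 log units; within the scatter). Neither trifluoromethyl nor methyl is therefore needed for the activity seen in these compounds, as compound 4, which carries neither group, stands level with both compound 1 and compound 3. Among these compounds, the ring itself gives the only step that clears the scatter, with phenyl in place of thiophen-3-yl giving an at least 2.4-fold lower number from compound 2 to compound 4 (0.39 log units; beyond the scatter), although the reading of compound 2 is a limit of the assay and not a number: the limit of > 50000 nM in this assay, at which 1 of the 4 values shown sits.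

The compounds shown leave open whether an amine or a carboxylic acid on this same aromatic carbon would stay level with hydrogen or move the number beyond the scatter. Going by these compounds, they also leave open whether a longer chain there would do so, and the true size of the step from the thiophen-3-yl ring remains unknown.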